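The source may hold more compounds than are shown below. What is called first, only, known or untested is meant among the compounds shown, and "the series" means these compounds.

In a functional assay on K562 cells (Homo sapiens) for cytotoxicity, read by MTT assay, with a stated time of 5 days (on this read-out lower numbers stand for stronger inhibition and higher numbers for weaker inhibition), compound 1 `COc1ccc(Cn2nncc2-c2cc(OC)c(OC)c(OC)c2)cc1O` gives 1830 nM. Swapping its hydroxy group for a nitro group leads to compound 2 `COc1ccc(Cn2nncc2-c2cc(OC)c(OC)c(OC)c2)cc1[N+](=O)[O-]`; the change is nitro in place of hydroxy on an aromatic carbon. For compound 2 this assay reports only a limit, > 10000 nM. The step of an at least 5.4-fold higher number from compound 1 to compound 2 (0.73 log units; beyond the scatter) thus marks a clear weakening of cytotoxic activity.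

Compound 3 `COc1ccc(-c2cn(-c3cc(OC)c(OC)c(OC)c3)nn2)cc1O` is built on a different core: the difference between the core of compound 1 and the core of compound 3 is not broken down here. For compound 3 this assay again reports only a limit, > 10000 nM.

Compound 4 `COc1ccc(-c2cn(-c3cc(OC)c(OC)c(OC)c3)nn2)cc1[N+](=O)[O-]` has not yet been measured. It arises from compound 3 by the same change that turned compound 1 into compound 2, namely (nitro in place of hydroxy on an aromatic carbon), at a position described in exactly the same way. When that change was made once before, it weakened activity. Because compound 3 already stands at the limit of > 10000 nM in this assay, at which 2 of the 3 values shown sit, the starting point of the new step is itself unknown beyond that limit, so the step is expected to read as a step that the limit leaves unreadable from compound 3 to compound 4. Compound 4 is therefore expected to give 30000 nM, most probably reported only as a limit. The expected range for compound 4 runs from 10000 nM to 100000 nM.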

Compound 4, half-maximal inhibitory concentration: > 10000 nM
Compound 4 was reported as a limit; the forecaster's own chance of this, stated with the estimate: 95%; the middle value lies beyond the limit too.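

In this assay compound 4 gives > 10000 nM, which is a limit and not a number. Within the data shown here, compound 3 also carries only a limit, so no step from compound 3 to compound 4 can be read: the limit of > 10000 nM in this assay, at which 3 of the 4 values shown sit. Going by these compounds, what stays open is how compound 2, compound 3 and compound 4 compare with one another, and whether nitro in place of hydroxy changes activity on the core of compound 3 at all.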